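Methoxy Added to an Aryl Ring in Pyrazole Chalcones

The source may report more compounds than this note shows. Statements on the series, on what has been measured and on what is new or still open speak of the compounds shown alone.

Measured compounds:
compound 1, `COc1ccc(-c2cc(/C=C/C(=O)c3ccc(N)cc3)[nH]n2)cc1`: -85%
compound 2, `COc1ccc(C(=O)/C=C/c2cc(-c3cc(OC)c(OC)c(OC)c3)n[nH]2)cc1OC`: -84%
compound 3, `COc1ccc(-c2cc(/C=C/C(=O)c3ccc(N)cc3)[nH]n2)cc1OC`: -99%

In a functional assay on OVCAR-3 cells (Homo sapiens) for cytotoxicity, read by sulforhodamine B assay, with a stated time of 48 h, tested at 100 uM (a lower number here means a stronger effect, a higher number a weaker effect of the compound at the concentration tested), compound 1 gives -85% and compound 3 gives -99%. The two differ by one change, (methoxy in place of hydrogen on an aromatic carbon), and that change made a step of a number 14 percentage points lower from compound 1 to compound 3 (beyond the scatter). Compound 2 gives -84%, within the scatter of compound 1; how the core of compound 2 differs from that of compound 1 is not broken down here.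

Compound 4, `COc1cc(C(=O)/C=C/c2cc(-c3cc(OC)c(OC)c(OC)c3)n[nH]2)cc(OC)c1OC`, has not yet been measured. It differs from compound 2 by methoxy in place of hydrogen on an aromatic carbon. Going by the values given here, this is the same kind of change as the one from compound 1 to compound 3, but the place is not identical: in compound 4 the new group is also meta to a methoxy group. Among the compounds with values here, with only one earlier example, the expectation rests on compound 3 and its step of a number 14 percentage points lower from compound 1 to compound 3 (beyond the scatter). For compound 4 a step of a number 8 percentage points lower from compound 2 to compound 4 (within the scatter) is estimated in this assay. Compound 4 is therefore expected to give about -92%, likely between -100% and -80%.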

Compound 4, a percentage reported as activity, at one concentration (the size of the read-out at that concentration, not a potency): -98%
For compound 4 the middle estimate is 6 percentage points above the measured one; the range from low to high includes it.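

In this assay, putting a methoxy group in place of a hydrogen on an aromatic carbon gave a number 14 percentage points lower from compound 2 to compound 4 (beyond the scatter). Set beside the earlier case, the same change produced a matching step on the two cores: the same change on two cores in this assay, a number 14 percentage points lower (beyond the scatter) from compound 1 to compound 3 and a number 14 percentage points lower (beyond the scatter) from compound 2 to compound 4, 0 percentage points apart, within the scatter of two such steps. This shows that the step carried over between these two pairs at the one concentration tested, but two pairs make no rule, the new group does not sit in an identical place in both, and a read-out at a single concentration is not a potency and does not explain why the step occurs.

The compounds shown leave open whether the same step would appear with the methoxy group at another place on these rings, or on a further core. They also leave open what a different group in the same place, such as an ethoxy group, a fluorine atom or a hydroxyl group, would do to the read-out.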